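A few compounds are considered here, and "the series" means these few. Any claim that something is new, unique, unknown or untested is made for them only; others in the source may bear on it.

In a functional assay on MDA-MB-231 cells (Homo sapiens) for antiproliferative activity, read by MTT assay, with a stated time of 24 h (a higher number here means a weaker inhibitor, a lower number a stronger inhibitor), the measured compounds are:
compound 1 `COc1ccc(-c2cc(/C=C/C(=O)c3ccc(OC)c(OC)c3)nc3cc(-c4ccccc4)nn23)cc1`: 8700 nM
compound 2 `COc1ccc(C(=O)/C=C/c2cc(-c3ccc(OC)c(OC)c3)n3nc(-c4ccccc4)cc3n2)cc1OC`: 2600 nM

Compound 1 gives the highest of the two numbers; its nearest neighbour is compound 2, with a 3.3-fold lower number from compound 1 to compound 2 (0.52 log units; beyond the scatter).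

Compound 3 `COc1ccc(-c2cc(/C=C/C(=O)c3ccccc3)nc3cc(-c4ccccc4)nn23)cc1` differs from compound 1 by phenyl in place of 3,4-dimethoxyphenyl on a carbonyl carbon. Within the data shown here, the only step bearing on it runs the other way in kind: adding a methoxy gave a 3.3-fold lower number from compound 1 to compound 2 (0.52 log units; beyond the scatter). Taking two methoxy groups away from compound 1 is therefore expected to raise the number in this assay beyond the scatter, by roughly a 2.3-fold higher number from compound 1 to compound 3 (0.36 log units; beyond the scatter). For compound 3 the estimate is 20000 nM, with a range from 7000 nM to 60000 nM.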

Compound 3, half-maximal inhibitory concentration: 9900 nM
Estimate against measurement, compound 3: 2.0-fold (0.31 log units) above; the measured number falls inside the stated range.
By their numbers in this assay, from the lowest: compound 2; then compounds 1 and 3 (each within the scatter of the next).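

In this assay, phenyl in place of 3,4-dimethoxyphenyl on a carbonyl carbon gives a 1.1-fold higher number from compound 1 to compound 3 (0.06 log units; within the scatter). At this place, the benzoyl of compound 3 therefore serves as well as the (3,4-dimethoxyphenyl)carbonyl of compound 1, so both methoxy groups can go without a change beyond the scatter. The gain in the methoxy step, a 3.3-fold lower number from compound 1 to compound 2 (0.52 log units; beyond the scatter), does not extend to this change, and nothing available accounts for the difference.

Going by these compounds, whether an amine or a carboxylic acid on this phenyl ring would move the number remains open.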